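Pyridin-2-ylmethyl in place of thiophen-2-ylmethyl on the amine

The source may hold more compounds than are shown below. What is called first, only, known or untested is meant among the compounds shown, and "the series" means these compounds.

Among the measured compounds shown here, in an assay on CHO cells for displacement of a labelled ligand from adenosine receptor A1 (Homo sapiens), read by scintillation counting, with a stated time of 90 min (on this read-out lower numbers stand for stronger inhibition and higher numbers for weaker inhibition), compound 1 `Nc1nc(NCc2cccs2)nc2sc(-c3ccco3)nc12` gives 12.5 nM, the lowest number of the three measured so far. Compound 2 `COc1cccc(CNc2nc(N)c3nc(-c4ccc(C)o4)sc3n2)c1` gives 70 nM in this assay, and compound 3 `Cc1ccc(-c2nc3c(N)nc(NCc4cccs4)nc3s2)o1` gives 71 nM. Compound 4 `Nc1nc(NCc2ccccn2)nc2sc(-c3ccco3)nc12` is not yet measured; against compound 1 the difference is pyridin-2-yl in place of thiophen-2-yl on a saturated chain carbon bound to a nitrogen on an aromatic ring. For the measured compounds named here, one measured step touches the same place: a 1.0-fold higher number from compound 2 to compound 3 (0.01 log units; within the scatter), so exchanging one aromatic group for another on that chain carbon left this assay unchanged. The other step, a 5.7-fold higher number from compound 1 to compound 3 (0.75 log units; beyond the scatter), concerns a methyl on an aromatic carbon elsewhere and does not bear on this change. A step no larger than the scatter is therefore expected, a 1.6-fold higher number from compound 1 to compound 4 (0.20 log units; within the scatter). Compound 4 is estimated at 20 nM in this assay, with a range from 6 nM to 70 nM.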

Compound 4, inhibition constant: 28 nM
Compound 4: the middle estimate sits 1.4-fold (0.15 log units) below what was measured; measured number inside the range.
By their numbers in this assay, from the lowest: compound 1; then compound 4; then compounds 2 and 3 (each within the scatter of the next).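

In this assay this place is not indifferent to the aromatic group it carries: pyridin-2-yl in place of thiophen-2-yl gives a 2.2-fold higher number from compound 1 to compound 4 (0.35 log units; beyond the scatter), whereas the earlier exchange here, a 1.0-fold higher number from compound 2 to compound 3 (0.01 log units; within the scatter), stayed within the scatter. Nothing at hand accounts for the modest step. Open, as far as these compounds go, is how a plain benzyl or a 2-phenylethyl chain would read in place of (thiophen-2-yl)methyl. Also open, from the compounds shown here alone, is whether the step from thiophen-2-yl to pyridin-2-yl keeps its size alongside the methyl of compound 3.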